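One Methyl Group on a Shared Core

The source may report more compounds than this note shows. Statements on the series, on what has been measured and on what is new or still open speak of the compounds shown alone.

Four compounds share one core and differ in two places. Compound 1 `COc1ccc(NC(=O)/C=C/c2coc3cc(OC)ccc3c2=O)cc1` carries a methoxy group and a 4-methoxyphenyl on its amide nitrogen; in a functional assay on HeLa cells (Homo sapiens) for inhibition, read by MTT assay, with a stated time of 48 h (a higher number here means a weaker inhibitor, a lower number a stronger inhibitor), compound 1 gives 13000 nM. Compound 2 `COc1ccc(NC(=O)/C=C/c2coc3cc(O)ccc3c2=O)cc1` has a hydroxy group where compound 1 has methoxy. In this assay compound 2 reaches only the limit of > 100000 nM, which is not a number. Compound 3 `Cc1ccccc1NC(=O)/C=C/c1coc2cc(O)ccc2c1=O` keeps the hydroxy group but its amide nitrogen bears 2-methylphenyl; in this assay compound 3 gives 8670 nM. Compound 4 `COc1ccc2c(=O)c(/C=C/C(=O)Nc3ccccc3C)coc2c1` is compound 3 with the change (methyl in place of hydrogen on an oxygen on an aromatic ring). The same change, (methyl in place of hydrogen on an oxygen on an aromatic ring), occurs between compound 2 and compound 1, where it gave an at least 7.6-fold lower number from compound 2 to compound 1 (0.88 log units; beyond the scatter); the step is known only as a lower bound because of the limit of > 100000 nM in this assay, at which 1 of the 3 values shown sits. The two cores differ by 2-methylphenyl in place of 4-methoxyphenyl on an amide-type nitrogen, a step of an at least 11-fold lower number from compound 2 to compound 3 (1.06 log units; beyond the scatter). The values of compound 1 and compound 3 lie within the scatter of each other. For compound 4 the expected step is a 2.5-fold lower number from compound 3 to compound 4 (0.39 log units; beyond the scatter), an estimate resting on the measured step of an at least 7.6-fold lower number from compound 2 to compound 1 (0.88 log units; beyond the scatter), which shows only that the methyl lowers the number without fixing its true size. Compound 4 is therefore expected to give 3500 nM, between 900 nM and 14000 nM.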

Compound 4, half-maximal inhibitory concentration: 7270 nM
For compound 4 the middle estimate is 2.1-fold (0.32 log units) below the measured one; the measured number falls inside the stated range.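

Carried onto the second core in this assay, the methyl on the oxygen gives a 1.2-fold lower number from compound 3 to compound 4 (0.08 log units; within the scatter), so the large step seen on the first core does not repeat there: the same change on two cores in this assay, an at least 7.6-fold lower number (0.88 log units; beyond the scatter) from compound 2 to compound 1 and a 1.2-fold lower number (0.08 log units; within the scatter) from compound 3 to compound 4, at least 6.4-fold (0.80 log units) apart, beyond the scatter of two such steps

The swap of 4-methoxyphenyl for 2-methylphenyl on the amide nitrogen behaves the same way, giving a 1.8-fold lower number from compound 1 to compound 4 (0.25 log units; within the scatter) once the methoxy group is in place: the same change on two cores in this assay, an at least 11-fold lower number (1.06 log units; beyond the scatter) from compound 2 to compound 3 and a 1.8-fold lower number (0.25 log units; within the scatter) from compound 1 to compound 4, at least 6.4-fold (0.80 log units) apart, beyond the scatter of two such steps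

Compound 2, the starting point of both large steps, stands at > 100000 nM, a limit and not a number, so the series shows that a step measured on one core need not hold on another but not how large the first step really is: the limit of > 100000 nM in this assay, at which 1 of the 4 values shown sits.

The compounds shown leave open what a longer chain such as ethyl on that oxygen would do to the number in this assay. They also leave open whether an amine or a carboxylic acid on the phenyl ring of the amide would change the picture, and whether the methyl step would stay this small on other cores.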